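This account rests on a few compounds, and the source may have more. Where it says the series, first, only, none or still open, it means among the compounds named here.

Measured compounds in a functional assay on the whole organism with Mus musculus as the target; a lower number here means that less compound is needed, a higher number that more compound is needed for the effect:
Compound 1 `CC(=O)N1CCCN(S(=O)(=O)c2ccc(F)cc2)CC1`: 1 mg/kg
Compound 2 `CCCS(=O)(=O)N1CCCN(C(C)=O)CC1`: > 10 mg/kg, a limit of the assay rather than a number
Compound 3 `CCC(=O)N1CCCN(S(=O)(=O)c2ccc(F)cc2)CC1`: 1 mg/kg

Compound 3 stands level with compound 1 in this assay; the step of no change at the digits printed from compound 1 to compound 3 (within the scatter), methyl in place of hydrogen on a saturated chain carbon bound to a carbonyl carbon, lies within the scatter. The third value in the set is the limit (the limit of > 10 mg/kg in this assay, at which 1 of the 3 values shown sits), which belongs to compound 2.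

Compound 4 `CCCS(=O)(=O)N1CCCN(C(=O)CC)CC1` is not yet measured. It differs from compound 3 in one place: propyl in place of 4-fluorophenyl on a sulfonyl sulfur. For the measured compounds named here, no step of the same kind has been measured between two compounds with numbers on both sides, so no step size can be carried over directly. Going by the values given here, the only guide is the pair of compound 1 and compound 2, which share this same exchange on the shared core. In this assay compound 1 gives 1 mg/kg. Compound 2 gives > 10 mg/kg, a limit of the assay and not a number. That pair suggests the exchange weakens the effect, so a step towards a higher dose is expected, though its true size is not known. Compound 4 is therefore expected to give 15 mg/kg, with a range from 4 mg/kg to 60 mg/kg. The step is thus estimated at a 15-fold higher number from compound 3 to compound 4 (1.18 log units; beyond the scatter), most likely reported only as a limit.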

Compound 4, minimum effective dose: > 10 mg/kg
Compound 4 was reported as a limit; the forecaster's own chance of this, stated with the estimate: 75%; the middle value lies beyond the limit too.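

The exchange of 4-fluorophenyl for propyl on a sulfonyl sulfur now has a readable step of its own in this assay, and it lies beyond the scatter: an at least 10-fold higher number from compound 3 to compound 4 (1.00 log units; beyond the scatter). The methyl in place of hydrogen on the saturated chain carbon bound to the carbonyl carbon made no difference to the dose at this sulfonyl group, no change at the digits printed from compound 1 to compound 3 (within the scatter), and the exchange on the sulfonyl sulfur costs effect with either carbonyl side chain, so this position, not that chain, sets the dose among the compounds shown. The pair of compound 1 and compound 2 had shown this loss on one side chain only, and the second propyl compound now reaches the same limit of the assay: the limit of > 10 mg/kg in this assay, at which 2 of the 4 values shown sit.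

On these data alone, how far the two propyl compounds lie past that limit stays open, and the step from compound 2 to compound 4 cannot be read, as both of its values are limits. The compounds shown also leave open whether the fluorine or the aromatic ring carries the effect, a question that a plain phenyl, a cyclohexyl or a longer chain such as hexyl on the sulfonyl sulfur would bear on.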